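Iodo to Methylsulfanyl: What Compound 3 Might Show

This account rests on a few compounds, and the source may have more. Where it says the series, first, only, none or still open, it means among the compounds named here.

Measured compounds:
compound 1, `O=C(/C=C/c1ccc2c(c1)B(O)OC2)c1ccc(-c2ccccc2)cc1`: 18300 nM
compound 2, `O=C(/C=C/c1ccc2c(c1)B(O)OC2)c1ccc(I)cc1`: > 100000 nM

In a toxicity assay on WI-38 cells (Homo sapiens) for cytotoxicity, read by MTT assay, with a stated time of 48 h (a lower number here means a stronger inhibitor, a higher number a weaker inhibitor), compound 1 gives 18300 nM. For compound 2 this assay reports only a limit, > 100000 nM. Among the compounds with values here, the one measured step, an at least 5.4-fold higher number from compound 1 to compound 2 (0.73 log units; beyond the scatter), thus rests on the limit of > 100000 nM in this assay, at which 1 of the 2 values shown sits, and is known only as a lower bound.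

Compound 3, `CSc1ccc(C(=O)/C=C/c2ccc3c(c2)B(O)OC3)cc1`, differs from compound 2 by methylsulfanyl in place of iodo on an aromatic carbon. Within the data shown here, no measured step covers the replacement of iodo by methylsulfanyl, and the only step available runs into a limit, so it gives little guidance on direction. Compound 3 is therefore expected to sit near compound 2, with a fair chance of again reaching only a limit. Compound 3 is estimated at 70000 nM, within 15000 nM to 300000 nM. The expected step is an at least 1.4-fold lower number from compound 2 to compound 3 (0.15 log units; that floor lies within the scatter), essentially no change beyond the scatter.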

Compound 3, half-maximal inhibitory concentration: 54300 nM
Compound 3: the middle estimate sits 1.3-fold (0.11 log units) above what was measured; the measured number falls inside the stated range.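

With methylsulfanyl on this aromatic carbon, compound 3 gives 54300 nM in this assay as a true number rather than a limit. The replacement of phenyl by methylsulfanyl thus gives a 3.0-fold higher number from compound 1 to compound 3 (0.47 log units; beyond the scatter) as a fully measured step, so the move away from phenyl at this position can now be sized without resting on a limit. The change from iodo to methylsulfanyl gives only an at least 1.8-fold lower number from compound 2 to compound 3 (0.26 log units; that floor lies within the scatter) and so fixes no size, since its floor does not separate the two groups: the limit of > 100000 nM in this assay, at which 1 of the 3 values shown sits.

Going by these compounds, whether an amine, a carboxylic acid or a longer chain on this carbon would fall nearer compound 1 or nearer compound 3 stays open. So does the true number for compound 2, whose reading in this assay remains a limit.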